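Adding a Methoxy Group to Compound 1

This account rests on a few compounds, and the source may have more. Where it says the series, first, only, none or still open, it means among the compounds named here.

Compound 1 `CC1=CC[C@H](C(C)(C)NC(=S)N/N=C/c2ccc(O)cc2)CC1` is the hydroxy-bearing member of this small set. In a functional assay on U-251 cells (Homo sapiens) for inhibition, read by sulforhodamine B assay, with a stated time of 48 h (a higher number here means a weaker inhibitor of growth, a lower number a stronger inhibitor of growth), compound 1 gives only a limit, > 100000 nM, so its true number is not known. Its nearest measured relatives are compound 2 `CC1=CC[C@H](C(C)(C)NC(=S)N/N=C/c2cccc(Cl)c2)CC1`, which in this assay gives 7900 nM, and compound 3 `CC1=CC[C@H](C(C)(C)NC(=S)N/N=C/c2ccc(Cl)cc2)CC1`, which in this assay gives 69500 nM. The change of 3-chlorophenyl in place of 4-hydroxyphenyl on a carbon with a double bond to nitrogen brings an at least 12-fold lower number from compound 1 to compound 2 (1.10 log units; beyond the scatter), whereas chloro in place of hydroxy on an aromatic carbon brings an at least 1.4-fold lower number from compound 1 to compound 3 (0.15 log units; that floor lies within the scatter). Between the two chloro compounds, 4-chlorophenyl in place of 3-chlorophenyl gives an 8.8-fold higher number from compound 2 to compound 3 (0.94 log units; beyond the scatter).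

Compound 4 `COc1cc(/C=N/NC(=S)NC(C)(C)[C@H]2CC=C(C)CC2)ccc1O` differs from compound 1 by methoxy in place of hydrogen on an aromatic carbon. For the measured compounds named here, no measured step adds a group while the hydroxy stays in place, so the change has no direct precedent here; the only steps known start from a compound that sits at the limit of > 100000 nM in this assay, at which 1 of the 3 values shown sits, and they tell how far removal of the hydroxy helps, not what a methoxy adds. With compound 1 at the floor of the assay, compound 4 is expected to remain weak: an estimate of 100000 nM, ranging from 40000 nM to 300000 nM, which would mean a number no higher from compound 1 to compound 4 (the limit leaves the size open), with a real chance that compound 4 is again reported only as a limit.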

Compound 4, concentration for 50% growth inhibition: 11700 nM
Beside the measured number, compound 4's estimate is 8.5-fold (0.93 log units) above it, outside the stated range (below it).
By their numbers in this assay, from the lowest: compounds 2 and 4 (each within the scatter of the next); then compound 3. At a limit, above all of these: compound 1.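

With the hydroxy group kept in place, methoxy in place of hydrogen brings an at least 8.5-fold lower number from compound 1 to compound 4 (0.93 log units; beyond the scatter) in this assay. The earlier steps shown here reached lower numbers only by replacing the 4-hydroxyphenyl group or its hydroxy, whereas this step shows that a compound that keeps the hydroxy can also read well clear of the limit, and that the aromatic carbon ortho to a hydroxy group is a place where a change can move the number beyond the scatter. The value for compound 1 is a limit and not a number, so the step has a floor but no known full size: the limit of > 100000 nM in this assay, at which 1 of the 4 values shown sits.

The compounds shown leave open whether this gain belongs to methoxy itself, or whether ethoxy, a longer alkoxy chain or an amine on the same aromatic carbon would bring a similar step. They also leave open whether methoxy needs the hydroxy group at all, a question that a compound with methoxy and a hydrogen in place of that hydroxy would address.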